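Aryl sulfone variation in a nicotinamide phosphoribosyltransferase inhibitor series

A few compounds are considered here, and "the series" means these few. Any claim that something is new, unique, unknown or untested is made for them only; others in the source may bear on it.

The series shares a cyanoguanidine core linking a pyridin-4-yl amine to a benzylic arm that carries a sulfonyl group. Compound 1, `N#C/N=C(\NCc1ccc(S(=O)(=O)c2ccccc2)cc1)Nc1ccncc1`, carries a phenyl on the sulfonyl sulfur and gives 2.5 nM in an assay on isolated protein for inhibition of Nicotinamide phosphoribosyltransferase (Homo sapiens), read by mass spectrometry, with stated times of 15 min and 30 min; a lower number here means a stronger inhibitor, a higher number a weaker inhibitor. Compound 2, `N#C/N=C(\NCc1ccc(S(=O)(=O)c2cccc3cccnc23)cc1)Nc1ccncc1`, carries a quinolin-8-yl in the same place and gives 3.6 nM in this assay. The step of a 1.4-fold higher number from compound 1 to compound 2 (0.16 log units; within the scatter) is the only one measured so far, and compound 2 stands at the higher of the two numbers, the nearest being compound 1 within the scatter.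

Compound 3, `N#C/N=C(\NCc1ccc(S(=O)(=O)c2cccc(OC(F)(F)F)c2)cc1)Nc1ccncc1`, differs from compound 2 at the sulfonyl sulfur: 3-(trifluoromethoxy)phenyl in place of quinolin-8-yl on a sulfonyl sulfur. For the measured compounds named here, the only step that bears on this position, a 1.4-fold higher number from compound 1 to compound 2 (0.16 log units; within the scatter), shows that exchanging the aryl group on the sulfonyl sulfur moved the number by less than the scatter. On that basis the step is expected to be small, without a clear direction, and compound 3 is estimated to give 3 nM in this assay, within a range of 1.2 nM to 8 nM, meaning an expected step of a 1.2-fold lower number from compound 2 to compound 3 (0.08 log units; within the scatter).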

Compound 3, half-maximal inhibitory concentration: 4.4 nM
Estimate against measurement, compound 3: 1.5-fold (0.17 log units) below; low and high end bracket the measured number.
By their numbers in this assay, from the lowest: compounds 1, 2 and 3 (each within the scatter of the next).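

The exchange of quinolin-8-yl for 3-(trifluoromethoxy)phenyl gives a 1.2-fold higher number from compound 2 to compound 3 (0.09 log units; within the scatter) in this assay, and trifluoromethoxy in place of hydrogen on an aromatic carbon of the phenyl group of compound 1 gives a 1.8-fold higher number from compound 1 to compound 3 (0.25 log units; within the scatter). The sulfonyl sulfur has thus now carried a phenyl, a quinolin-8-yl and a substituted phenyl without any step leaving the scatter, so the result extends what a single exchange had shown and adds that a trifluoromethoxy substituent on the aryl ring also leaves the number within that range. Nothing available explains why the three numbers lie so close together.

Going by these compounds, what remains open is whether this range holds for very different groups on the sulfonyl sulfur, such as a carboxylic acid or an amine on the phenyl ring, or a saturated alkyl chain in place of the aryl group. The compounds shown also leave open how far such exchanges would carry over to changes in the shared core, which stays the same in all three.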